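The source may hold more compounds than are shown below. What is called first, only, known or untested is meant among the compounds shown, and "the series" means these compounds.

Compound 1 `O=C(Nc1nc2ccccc2s1)c1cn(-c2ccccc2)nc1-c1ccccc1`: 13500 nM
Compound 2 `O=C(Nc1nc2ccc(F)cc2s1)c1cn(-c2ccccc2)nc1-c1ccccc1`: 10200 nM
Compound 3 `O=C(Nc1nc2ccc(Cl)cc2s1)c1cn(-c2ccccc2)nc1-c1ccccc1`: 7670 nM

These three values come from a functional assay on A549 cells (Homo sapiens) for cytotoxicity, read by MTT assay, with a stated time of 72 h; a lower number here means a stronger inhibitor, a higher number a weaker inhibitor. Compound 1 gives the highest number of the three, yet its steps to compound 2 a 1.3-fold lower number from compound 1 to compound 2 (0.12 log units; within the scatter) and to compound 3 a 1.8-fold lower number from compound 1 to compound 3 (0.25 log units; within the scatter) both stay within the scatter, so no order among them can be claimed. Compound 4 `O=C(Nc1nc2ccccc2s1)c1cn(-c2ccccc2)nc1-c1ccc(F)cc1` has not yet been measured in this assay. It differs from compound 1 by fluoro in place of hydrogen on an aromatic carbon. The closest measured comparison is the step from compound 1 to compound 2, the same kind of exchange on an aromatic carbon of a different ring, which stayed within the scatter. On that basis no step beyond the scatter is expected for compound 4 a 1.2-fold lower number from compound 1 to compound 4 (0.09 log units; within the scatter). Compound 4 is therefore estimated at 11000 nM, with a range from 5000 nM to 25000 nM.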

Compound 4, half-maximal inhibitory concentration: 9010 nM
Compound 4: the middle estimate sits 1.2-fold (0.09 log units) above what was measured, within the range that was stated.
By their numbers in this assay, from the lowest: compounds 3, 4, 2 and 1 (each within the scatter of the next).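

Going by these compounds alone, compound 4 gives a first reading of the phenyl to 4-fluorophenyl change, para to a large group, and in this assay this is a 1.5-fold lower number from compound 1 to compound 4 (0.18 log units; within the scatter). Fluoro at this position therefore leaves the number as close to that of the unsubstituted parent as fluoro on the other ring does, so neither placement separates from compound 1. Nothing available here explains how this group acts at this position. Going by these compounds, whether an amine or a carboxylic acid at the same position would move the number beyond the scatter remains open.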